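Swapping the carbonyl substituent on a shared biaryl-pyridine core

The source may report more compounds than this note shows. Statements on the series, on what has been measured and on what is new or still open speak of the compounds shown alone.

Of the compounds shown here, two with the same core have been measured in an assay on isolated protein (Aquatica lateralis) for inhibition of Luciferin 4-monooxygenase (Luciola lateralis), read by a luciferase reporter, tested at 10 uM; on this read-out higher numbers stand for more inhibition at the one concentration tested (going by the name of the read-out) and lower numbers for less inhibition. Compound 1 `O=C(Nc1ccccc1)Nc1ccc(-c2ccccc2)cn1` carries an anilino group on the carbonyl carbon, and in this assay compound 1 gives 20%. Compound 2 `CCCC(=O)Nc1ccc(-c2ccccc2)cn1` carries a propyl group at the same place, and in this assay compound 2 gives 22%. Among the measured compounds shown here, the one step between them, a number 2 percentage points higher from compound 1 to compound 2 (within the scatter), is within the scatter, so compound 2 stands alongside compound 1 with no separation that the assay can resolve.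

Compound 3 `O=C(Nc1ccc(-c2ccccc2)cn1)c1ccc(Cl)cc1` is not yet measured. It differs from compound 2 by 4-chlorophenyl in place of propyl on a carbonyl carbon. For the measured compounds named here, the only measured step that bears on this change is the one on the same carbonyl carbon, a number 2 percentage points higher from compound 1 to compound 2 (within the scatter), which is within the scatter. Going by the values given here, with that as the sole guide, the step of a number 2 percentage points higher from compound 2 to compound 3 (within the scatter) is expected to stay within the scatter, in no particular direction. Compound 3 is therefore estimated to give about 24%, with a range from 5% to 45%.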

Compound 3, a percentage reported as inhibition, at one concentration (the size of the read-out at that concentration, not a potency): 0%
The estimate for compound 3 lay 24 percentage points above the measured number; the measured number lies below the stated range.
By their numbers in this assay, from the lowest: compound 3; then compounds 1 and 2 (each within the scatter of the next).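

In this assay, 4-chlorophenyl on the carbonyl carbon gives a number 22 percentage points lower from compound 2 to compound 3 (beyond the scatter) and, set against anilino at the same place, a number 20 percentage points lower from compound 1 to compound 3 (beyond the scatter), so this position can move the read-out, which the earlier pair of compounds could not show. The presence of a six-membered aromatic ring does not sort the three compounds on its own: the anilino group of compound 1 also holds such a ring, yet the step to the propyl group is a number 2 percentage points higher from compound 1 to compound 2 (within the scatter). Nothing available here explains the drop seen with 4-chlorophenyl.

These compounds do not tell whether the loss goes with the chlorine, with the ring joined to the carbonyl carbon, or with the two together, and a plain phenyl group at this place would help to separate those readings. A longer chain or a carboxylic acid on the same carbonyl carbon would show whether any group there can raise the inhibition above the level shared by compound 1 and compound 2.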